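The compounds below may be only part of what the source reports. "The series", "measured", "known", "first", "only" and "open" are said of these compounds alone.

Compound 1 `CNc1nc(C)c(C(=O)N/N=C/c2ccccc2C(F)(F)F)s1`: > 100 ug/mL
Compound 2 `CN(C(=O)NC(=O)c1ccccc1F)c1nc(C(F)(F)F)c(C(=O)N/N=C/c2cc(C(F)(F)F)cc(C(F)(F)F)c2)s1`: 6.16 ug/mL

Compound 2 is the only one of the two that gives a number in a functional assay on MCF7 cells (Homo sapiens) for inhibition, read by MTT assay, with a stated time of 72 h (on this read-out higher numbers stand for weaker inhibition and lower numbers for stronger inhibition), where compound 2 shows 6.16 ug/mL. Compound 1 reaches only a limit of the assay and not a number, reported as > 100 ug/mL. The other value shown thus sits at the limit of > 100 ug/mL in this assay, at which 1 of the 2 values shown sits. Compound 3 `CN(C(=O)NC(=O)c1ccc(F)c(F)c1)c1nc(C(F)(F)F)c(C(=O)N/N=C/c2cc(C(F)(F)F)cc(C(F)(F)F)c2)s1` has not yet been measured in this assay. It differs from compound 2 in one place: 3,4-difluorophenyl in place of 2-fluorophenyl on a carbonyl carbon. Within the data shown here, no step between measured compounds covers such a change, so there is nothing to set its size against. The expected step is a 1.0-fold lower number from compound 2 to compound 3 (0.01 log units; within the scatter), none beyond the usual scatter in either direction. Compound 3 is therefore estimated at 6 ug/mL, with a range from 2.5 ug/mL to 15 ug/mL.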

Compound 3, half-maximal inhibitory concentration: 2.61 ug/mL
For compound 3 the middle estimate is 2.3-fold (0.36 log units) above the measured one; the range from low to high includes it.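

Among these compounds, replacing 2-fluorophenyl with 3,4-difluorophenyl on a carbonyl carbon gives a 2.4-fold lower number from compound 2 to compound 3 (0.37 log units; beyond the scatter) in this assay and is the first measured step at this position. It shows that this position is not silent: with the rest of the molecule unchanged, the aryl group on the carbonyl carbon alone moves the read-out beyond the usual scatter, though only modestly. Nothing measured here accounts for the size or direction of this step.

Among the compounds shown here, the single swap changes both the number of fluorines and where they stand, so the two changes cannot be separated, and one step cannot show a trend. Going by these compounds, it also remains open how this position would respond to an amine, a carboxylic acid or a longer alkyl chain in place of the fluorinated phenyl ring.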